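Swapping the Aryl Group on a Shared Core

The compounds below may be only part of what the source reports. "The series", "measured", "known", "first", "only" and "open" are said of these compounds alone.

Going by the values given here, compound 1 `C=CCn1c(=O)/c(=C\c2cc(F)ccc2C)[nH]c(=O)/c1=C\c1ccccc1OC` is the only member of this small set with a numerical result: in a functional assay on HeLa cells (Homo sapiens) for cytotoxicity, read by CCK-8 assay, with a stated time of 72 h (on this read-out higher numbers stand for weaker inhibition and lower numbers for stronger inhibition), compound 1 gives 2900 nM. Compound 2 `C=CCn1c(=O)/c(=C\c2cc(OC)c(OC)c(OC)c2)[nH]c(=O)/c1=C\c1cccc(Br)c1` carries two different aryl groups on the same core; in this assay compound 2 is recorded as "not active" (no number reported), with no number behind that entry. Among the compounds with values here, no pair of measured compounds differs in a single place, so nothing here calibrates how a change of one aryl group moves the result. The unmeasured compound 3 `C=CCn1c(=O)/c(=C\c2cc(Br)ccc2F)[nH]c(=O)/c1=C\c1ccccc1OC` differs from compound 1 by 5-bromo-2-fluorophenyl in place of 5-fluoro-2-methylphenyl on a double-bonded chain carbon bound to an aromatic carbon. Within the data shown here, with no measured step to lean on, the expected step of a 1.0-fold higher number from compound 1 to compound 3 (0.01 log units; within the scatter) is small, in no clear direction, and probably within the usual scatter. Compound 3 is therefore estimated at about 3000 nM in this assay, within a range from 1200 nM to 8000 nM.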

Compound 3, half-maximal inhibitory concentration: 34600 nM
Compound 3: the middle estimate sits 12-fold (1.06 log units) below what was measured; measured number above the stated range.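

In this assay, placing 5-bromo-2-fluorophenyl where compound 1 carries 5-fluoro-2-methylphenyl, on a double-bonded chain carbon bound to an aromatic carbon, gives a large change (a 12-fold higher number from compound 1 to compound 3 (1.08 log units; beyond the scatter)). Going by these compounds alone, this is the first calibration of this position: the two groups have the same heavy-atom count, neither has a hydrogen-bond donor or acceptor, and neither has a net charge, yet the number still moves well beyond the scatter. No measurement shown here accounts for this step.

The compounds shown leave open whether the bromine, the loss of the methyl group, or both together produce the step. They also leave open how an amine or a carboxylic acid on this aryl ring would move the result on the shared core.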